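From cyclohexylmethyl to 3-chloro-4-fluorobenzyl on the shared core

The source may report more compounds than this note shows. Statements on the series, on what has been measured and on what is new or still open speak of the compounds shown alone.

In a toxicity assay on GES1 cells (Homo sapiens) for inhibition, read by MTT assay, with a stated time of 72 h (on this read-out lower numbers stand for stronger inhibition and higher numbers for weaker inhibition), compound 3 (`Cc1cc(N2CC[C@@H](C)[C@@H](N(C)c3ncnc4[nH]ccc34)C2)n2nc(SCC3CCCCC3)nc2n1`) gives 98200 nM. Its nearest neighbour by number is compound 2 (`Cc1cc(N2CC[C@@H](C)[C@@H](N(C)c3ncnc4[nH]ccc34)C2)n2ncnc2n1`), at 57900 nM, and the comparison shows a 1.7-fold higher number from compound 2 to compound 3 (0.23 log units; within the scatter), so the two cannot be ranked. Compound 1 (`Cc1cc(N2CC[C@@H](C)[C@@H](N(C)c3ncnc4[nH]ccc34)C2)n2nc(SCc3ccc(Cl)cc3)nc2n1`) gives > 100000 nM, which is a limit of the assay and not a number.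

Compound 4 (`Cc1cc(N2CC[C@@H](C)[C@@H](N(C)c3ncnc4[nH]ccc34)C2)n2nc(SCc3ccc(F)c(Cl)c3)nc2n1`) differs from compound 3 in one place: 3-chloro-4-fluorophenyl in place of cyclohexyl on a saturated chain carbon bound to a sulfur. Here 3-chloro-4-fluorophenyl stands in place of cyclohexyl on a saturated chain carbon bound to a sulfur, so cyclohexylmethyl becomes 3-chloro-4-fluorobenzyl.

The closest measured precedent is the exchange of an aromatic ring for cyclohexyl at this same place, which gave an at least 1.0-fold lower number from compound 1 to compound 3 (0.00 log units; that floor lies within the scatter). Removing the whole substituent from compound 1 gave an at least 1.7-fold lower number from compound 1 to compound 2 (0.23 log units; that floor lies within the scatter). Neither step establishes a change beyond the scatter, so no step beyond it is expected for compound 4 in this assay, and the assay may again report only a limit. The expected change is a 1.1-fold lower number from compound 3 to compound 4 (0.04 log units; within the scatter). For compound 4 the estimated value is 90000 nM, with an expected range of 40000 nM to 200000 nM.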

Compound 4, half-maximal inhibitory concentration: > 100000 nM
Compound 4 ended at the assay's limit; the forecaster's own chance of this, stated with the estimate: 45%; at least 1.1-fold (0.04 log units) between middle value and limit.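

Compound 4 now joins compound 1 at a limit of the assay, which is not a number, so two different chlorine-bearing benzyl groups on the sulfur end the same way in this assay: the limit of > 100000 nM in this assay, at which 2 of the 4 values shown sit.

The readable steps, an at least 1.0-fold higher number from compound 3 to compound 4 (0.00 log units; that floor lies within the scatter) and an at least 1.7-fold higher number from compound 2 to compound 4 (0.23 log units; that floor lies within the scatter), give only floors, and neither establishes a change from cyclohexylmethyl to 3-chloro-4-fluorobenzyl or from hydrogen to (3-chloro-4-fluorobenzyl)sulfanyl, while the step between the two limits cannot be read. Across the four compounds shown, then, this position has yet to produce a difference beyond the scatter, whether the substituent is absent or carries a cyclohexyl, a 4-chlorophenyl or a 3-chloro-4-fluorophenyl ring.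

The compounds shown leave open how far compound 1 and compound 4 really lie from each other and from compound 3, since a limit cannot place them. They also leave open whether a different kind of group at this place, such as an amine, a carboxylic acid or a longer chain between the sulfur and the ring, would give a step beyond the scatter in this assay.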